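The source may hold more compounds than are shown below. What is called first, only, known or untested is meant among the compounds shown, and "the series" means these compounds.

In a functional assay on PA-1 cells (Homo sapiens) for antiproliferative activity, read by MTT assay, with a stated time of 48 h (a higher number here means a weaker inhibitor, a lower number a stronger inhibitor), compound 3 `CCN1C(=O)C(O)(Cc2nnn[nH]2)c2cc(Br)ccc21` is reported as > 100000 nM, which is a limit of the assay and not a number. Compound 2 `CN1C(=O)C(O)(Cc2nnn[nH]2)c2cc(Br)ccc21` is also known only as a limit, > 100000 nM. The same holds for compound 1 `O=C1N(Cc2ccc(Br)cc2)c2ccc(F)cc2C1(O)Cc1nnn[nH]1`, which carries a 4-bromobenzyl group and gives the limit > 100000 nM. The whole set therefore sits at one ceiling: the limit of > 100000 nM in this assay, at which 3 of the 3 values shown sit.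

The next change makes compound 4 `O=C1N(Cc2ccc(Br)cc2)c2ccc(Br)cc2C1(O)Cc1nnn[nH]1`. It places 4-bromophenyl in place of methyl on a saturated chain carbon bound to an amide-type nitrogen in a ring, so that ethyl becomes 4-bromobenzyl: 4-bromophenyl in place of methyl on a saturated chain carbon bound to an amide-type nitrogen in a ring.

Among the measured compounds shown here, the only measured step at this place is a step that the two limits leave unreadable from compound 2 to compound 3, so it offers no size to carry forward. The closest guide is compound 1, whose 4-bromobenzyl group came with the limit > 100000 nM. For the measured compounds named here, no measured compound in this assay has yet given a real number, so no clear gain in potency can be predicted, and compound 4 will most likely stay at the limit or close to it. The expected change is small, a number no higher from compound 3 to compound 4 (the limit leaves the size open), with any movement more likely toward a stronger inhibitor. For compound 4 the estimated value is 100000 nM, with an expected range from 25000 nM to 200000 nM.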

Compound 4, half-maximal inhibitory concentration: > 100000 nM
Compound 4: only a limit was reported (the forecaster's own chance of this, stated with the estimate: 70%); the middle value sits exactly at the limit.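

In this assay compound 4 gives > 100000 nM, a limit of the assay and not a number. Among the compounds shown here, no step from compound 1, compound 2 or compound 3 to compound 4 can be read, as all four share one ceiling: the limit of > 100000 nM in this assay, at which 4 of the 4 values shown sit. The compounds shown leave open whether any change to the shared core would give a real number.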